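Trading the allyl urea for an acetyl group

This account rests on a few compounds, and the source may have more. Where it says the series, first, only, none or still open, it means among the compounds named here.

Compound 1 `C=CCNC(=O)N1CCN(c2cc(N)c3cc(OC)c(OC)cc3n2)CC1` gives the lower of the two numbers measured in an assay on brain for displacement of a labelled ligand from Adrenergic receptor alpha-1 (Rattus norvegicus) (on this read-out higher numbers stand for weaker inhibition and lower numbers for stronger inhibition), at 0.29 nM. Compound 2 `COc1cc2nc(N(C)C)cc(N)c2cc1OC` is the weaker of the two in this assay, giving 11.4 nM, and the gap between them lies beyond the usual scatter. Compound 3 `COc1cc2nc(N3CCN(C(C)=O)CC3)cc(N)c2cc1OC` differs from compound 1 in one place: methyl in place of allylamino on a carbonyl carbon. Among the measured compounds shown here, no measured pair shows a step of this kind. A modest weakening is expected, a 3.4-fold higher number from compound 1 to compound 3 (0.54 log units; beyond the scatter), still far short of the number seen for compound 2 with its 11.4 nM. Compound 3 is therefore estimated at 1 nM, with a range from 0.3 nM to 3.5 nM.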

Compound 3, inhibition constant: 1.17 nM
Compound 3: the middle estimate sits 1.2-fold (0.07 log units) below what was measured; the measured number falls inside the stated range.
By their numbers in this assay, from the lowest: compound 1; then compound 3; then compound 2.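

In this assay, methyl in place of allylamino on a carbonyl carbon gives a 4.0-fold higher number from compound 1 to compound 3 (0.61 log units; beyond the scatter) and so counts as a modest step. The allylamino group is therefore not required for a low number at this position, since compound 3 still gives 1.17 nM without it, although its loss exceeds the usual scatter. Nothing available explains the size of this step.

On these data alone, it remains open whether the double bond, the amide hydrogen or the chain length accounts for the step. A propyl urea or a methyl urea on the same carbonyl carbon would help separate these.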